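This account rests on a few compounds, and the source may have more. Where it says the series, first, only, none or still open, it means among the compounds named here.

Measured compounds:
- compound 1 `Cc1ccc2c(=O)n(C)c3c(c2c1)CCOc1ccccc1-3`: 33600 nM
- compound 2 `COc1cc2c3c(n(C)c(=O)c2cc1OC)-c1ccccc1OCC3`: 34800 nM

The two measured compounds were tested in a functional assay on HL-60 cells (Homo sapiens) for cytotoxicity, read by sulforhodamine B assay; on this read-out higher numbers stand for weaker inhibition and lower numbers for stronger inhibition. Compound 1 gives 33600 nM in this assay, and compound 2 gives 34800 nM. The two numbers lie within the scatter of each other, so neither compound can be called stronger or weaker on this evidence; both sit at a high concentration, which means weak inhibition.

Compound 3 `COc1ccc(Cn2c3c(c4cc(C)ccc4c2=O)CCOc2ccccc2-3)cc1` has not yet been measured in this assay. It differs from compound 1 in one place: 4-methoxyphenyl in place of hydrogen on a saturated chain carbon bound to an aromatic nitrogen. For the measured compounds named here, no pair of measured compounds shows the effect of such a change, so no step size can be read from the data. A step of modest size in this assay is expected, with the direction uncertain and a wide range around it: a 1.7-fold lower number from compound 1 to compound 3 (0.23 log units; within the scatter). Compound 3 is therefore estimated at 20000 nM, with a range from 5000 nM to 80000 nM.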

Compound 3, half-maximal inhibitory concentration: 9260 nM
Beside the measured number, compound 3's estimate is 2.2-fold (0.33 log units) above it, and the stated range covers the measured number.
By their numbers in this assay, from the lowest: compound 3; then compounds 1 and 2 (each within the scatter of the next).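

In this assay, putting 4-methoxyphenyl on the saturated chain carbon bound to an aromatic nitrogen gives a 3.6-fold lower number from compound 1 to compound 3 (0.56 log units; beyond the scatter) and so moves the number beyond the scatter. This shows that the position can carry a much larger group than the methyl of compound 1 without losing inhibition, and that changing it can lower the number. Nothing available explains why this change lowers the number.

From the compounds shown here alone, it remains open whether the lower number comes from the aromatic ring itself or from the methoxy group on it, and whether the same change would have a similar effect on the core of compound 2. A plain benzyl group, a longer chain or an amine at this position would help to tell these possibilities apart.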